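From 3,4-dibromophenyl to 2,5-difluorophenyl

This account rests on a few compounds, and the source may have more. Where it says the series, first, only, none or still open, it means among the compounds named here.

- compound 1 `COc1cccc(/C=C2\SC(=S)N(NS(=O)(=O)c3ccccc3)C2=O)c1`: > 50000 nM
- compound 2 `O=C1/C(=C/c2ccc(Br)c(Br)c2)SC(=S)N1NS(=O)(=O)c1ccccc1`: > 50000 nM

In a functional assay on ECV-304 cells (Homo sapiens) for cytotoxicity (a lower number here means a stronger inhibitor, a higher number a weaker inhibitor), compound 2 stands at > 50000 nM, which is a limit and not a number. Compound 1 shows > 50000 nM, also a limit. Within the data shown here, the only measured step is a step that the two limits leave unreadable from compound 1 to compound 2, so it offers no size to build on. The one thing the data do show is the limit of > 50000 nM in this assay, at which 2 of the 2 values shown sit, and nothing in them yet marks a readable inhibitor.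

Next comes compound 3 `O=C1/C(=C/c2cc(F)ccc2F)SC(=S)N1NS(=O)(=O)c1ccccc1`, with the change (2,5-difluorophenyl in place of 3,4-dibromophenyl on a double-bonded chain carbon bound to a double-bonded ring carbon). Among the measured compounds shown here, no step of known size bears on this swap, so no shift in either direction is expected in this assay beyond the scatter. Compound 3 is expected near 50000 nM, with an estimated range from 20000 nM to 100000 nM, and another limit is the likeliest report. This estimate means an expected a number no higher from compound 2 to compound 3 (the limit leaves the size open), which remains tentative.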

Compound 3, half-maximal inhibitory concentration: > 50000 nM
Compound 3 ended at the assay's limit; the forecaster's own chance of this, stated with the estimate: 80%; the middle value lies on the limit itself.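

Compound 3 also ends at a limit, so no step among compound 1, compound 2 and compound 3 can be read: the limit of > 50000 nM in this assay, at which 3 of the 3 values shown sit.

The compounds shown leave open whether any group on the double-bonded chain carbon would give a readable inhibitor.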